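The source may report more compounds than this note shows. Statements on the series, on what has been measured and on what is new or still open speak of the compounds shown alone.

Measured so far:
- compound 1, `O=C(N/N=C/c1cccnc1)c1cccnc1Nc1cccc(C(F)(F)F)c1`: 59.1%
- compound 2, `O=C(N/N=C/c1ccncc1)c1cccnc1Nc1cccc(C(F)(F)F)c1`: 68.1%
- compound 3, `CNc1ncccc1C(=O)N/N=C/c1cccnc1`: 66.3%

All three numbers come from a functional assay on the whole organism (strain Wistar) for inhibition, with Rattus norvegicus as the target, read by paw edema, with a stated time of 30 min, at a dose of 10 mg/kg by the intraperitoneal route; a higher number here means more inhibition at the dose given (going by the name of the read-out), a lower number less inhibition. Compound 1 and compound 2 share one core; compound 3 has another. The difference between the two cores is not broken down here.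

Within the first core, compound 2 differs from compound 1 by pyridin-4-yl in place of pyridin-3-yl on a carbon with a double bond to nitrogen. That step gave a number 9 percentage points higher from compound 1 to compound 2 (within the scatter).

Compound 4, `CNc1ncccc1C(=O)N/N=C/c1ccncc1`, is not yet measured. It differs from compound 3 by pyridin-4-yl in place of pyridin-3-yl on a carbon with a double bond to nitrogen. Going by the values given here, this is the same kind of change as the one from compound 1 to compound 2, and it sits on the same kind of carbon.

For compound 4 the expected step in this assay is a number 4.7 percentage points higher from compound 3 to compound 4 (within the scatter), resting on the step seen from compound 1 to compound 2 of a number 9 percentage points higher from compound 1 to compound 2 (within the scatter), applied once more to compound 3 with its 66.3%. The estimate for compound 4 in this assay is 71%, expected to fall between 58% and 82%.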

Compound 4, a percentage reported as inhibition, in the whole organism at one dose (the size of the read-out at that dose, not a potency): 63.2%
The estimate for compound 4 lay 7.8 percentage points above the measured number; the range from low to high includes it.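

In this assay, pyridin-4-yl in place of pyridin-3-yl on a carbon with a double bond to nitrogen gave a number 3.1 percentage points lower from compound 3 to compound 4 (within the scatter). Set beside the step on the core of compound 1, the two results do not differ beyond what repeated measurements would give: the same change on two cores in this assay, a number 9 percentage points higher (within the scatter) from compound 1 to compound 2 and a number 3.1 percentage points lower (within the scatter) from compound 3 to compound 4, 12.1 percentage points apart, within the scatter of two such steps. This is consistent with the change carrying from one core to the other, but it does not show a real effect on either core, and the opposite signs of the two steps cannot be read as a reversal, since neither step stands clear of the scatter and each rests on a single dose.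

The compounds shown leave open whether any other group on that carbon, such as an unsubstituted phenyl or a phenyl bearing a carboxylic acid, would shift the inhibition beyond the scatter. Also open, as far as these compounds go, is whether a longer alkyl chain in place of the methyl group of compound 3 would alter the reading.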